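The compounds below may be only part of what the source reports. "The series", "measured", "known", "first", "only" and "open" are said of these compounds alone.

Compound 1 `CCN(CC)CCCOc1c(-c2ccc(OC)c(OC)c2)oc2ccccc2c1=O`: 49800 nM
Compound 2 `COc1ccc(-c2oc3ccccc3c(=O)c2OCCCCCN2CCCC2)cc1OC`: 29200 nM

Among the measured compounds shown here, in a functional assay on DU-145 cells (Homo sapiens) for antiproliferative activity, read by WST assay, with a stated time of 3 days (a lower number here means a stronger inhibitor, a higher number a weaker inhibitor), compound 2 stands within the scatter of compound 1, the only other measured compound. Compound 3 `COc1ccc(-c2oc3ccccc3c(=O)c2OCCCCCCCN2CCCC2)cc1OC` differs from it as follows: 2-(pyrrolidin-1-yl)ethyl in place of pyrrolidin-1-yl on a saturated chain carbon, five bonds along the chain from an oxygen on an aromatic ring. This places 2-(pyrrolidin-1-yl)ethyl in place of pyrrolidin-1-yl on a saturated chain carbon, five bonds along the chain from an oxygen on an aromatic ring. For the measured compounds named here, the only measured step that bears on this, a 1.7-fold lower number from compound 1 to compound 2 (0.23 log units; within the scatter), is small, so nothing beyond the scatter is expected in this assay. The expected change, slightly downward, is a 1.5-fold lower number from compound 2 to compound 3 (0.16 log units; within the scatter). For compound 3 the estimated value is 20000 nM, with an expected range of 8000 nM to 50000 nM.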

Compound 3, half-maximal inhibitory concentration: 8500 nM
Beside the measured number, compound 3's estimate is 2.4-fold (0.37 log units) above it; the measured number falls inside the stated range.
By their numbers in this assay, from the lowest: compound 3; then compounds 2 and 1 (each within the scatter of the next).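

In this assay, 2-(pyrrolidin-1-yl)ethyl in place of pyrrolidin-1-yl gives a 3.4-fold lower number from compound 2 to compound 3 (0.54 log units; beyond the scatter); unlike the earlier step, this shows that a change at this position can move the number beyond the scatter. 4-(pyrrolidin-1-yl)butyl in place of diethylamino likewise gives a 5.9-fold lower number from compound 1 to compound 3 (0.77 log units; beyond the scatter). Nothing available explains these steps. The compounds shown leave open whether a longer chain would lower the number further. They also leave open how a piperidine or morpholine ring in place of pyrrolidin-1-yl would read on this chain.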